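Changing one aryl group on a cytotoxic compound

The source may hold more compounds than are shown below. What is called first, only, known or untested is meant among the compounds shown, and "the series" means these compounds.

Measured in a functional assay on A549 cells (Homo sapiens) for cytotoxicity, read by MTT assay, with a stated time of 48 h; a lower number here means a stronger inhibitor, a higher number a weaker inhibitor:
- Compound 1 `COc1cc(C2=NOC(c3cc(OC)c(OC)c(OC)c3)C2)ccc1O`: 2600 nM
- Compound 2 `COc1ccc(C2=NOC(COc3ccc(-c4nnnn4-c4cc(OC)c(OC)c(OC)c4)cc3N)C2)cc1OC`: 2520 nM
- Compound 3 `COc1ccc(C2=NOC(COc3ccc(-c4nnnn4-c4cc(OC)c(OC)c(OC)c4)cc3N)C2)cc1O`: 2130 nM

All three values lie close together. The value of compound 3 is within the usual scatter of those of both compound 1 and compound 2, so the numbers do not separate these compounds.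

Compound 4 `COc1cc(-n2nnnc2-c2ccc(OCC3CC(c4ccc(C(F)(F)F)cc4)=NO3)c(N)c2)cc(OC)c1OC` differs from compound 3 in one place: 4-(trifluoromethyl)phenyl in place of 3-hydroxy-4-methoxyphenyl on a carbon with a double bond to nitrogen. Here 4-(trifluoromethyl)phenyl replaces 3-hydroxy-4-methoxyphenyl on a carbon with a double bond to nitrogen.

Among the compounds with values here, only one measured step touches the group that leaves: a 1.2-fold lower number from compound 2 to compound 3 (0.07 log units; within the scatter). That step swaps hydrogen for methyl on an oxygen and stays within the scatter. Within the data shown here, it is a weak guide, since the new change replaces the whole group and no measured compound carries 4-(trifluoromethyl)phenyl. No step beyond the scatter is therefore expected in this assay, and no direction is favoured, though the uncertainty is wide.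

The expected change is a 1.2-fold higher number from compound 3 to compound 4 (0.07 log units; within the scatter).

For compound 4 the estimated value is 2500 nM, with an expected range of 900 nM to 7000 nM.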

Compound 4, half-maximal inhibitory concentration: 1220 nM
For compound 4 the middle estimate is 2.0-fold (0.31 log units) above the measured one; the range from low to high includes it.
By their numbers in this assay, from the lowest: compounds 4, 3, 2 and 1 (each within the scatter of the next, the first and the last beyond it).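

The position on the carbon with a double bond to nitrogen takes more than a small edit. The earlier step changed only a methyl on an oxygen, whereas here 4-(trifluoromethyl)phenyl, with 0 hydrogen-bond donors and 0 hydrogen-bond acceptors, replaces the whole aryl group and cytotoxicity is kept (in this assay). Replacing 3-hydroxy-4-methoxyphenyl does not separate the compounds (a 1.7-fold lower number from compound 3 to compound 4 (0.24 log units; within the scatter)), but replacing 3,4-dimethoxyphenyl gives a modest gain (a 2.1-fold lower number from compound 2 to compound 4 (0.32 log units; beyond the scatter)), and nothing measured here accounts for either result.

From the compounds shown here alone, it remains open whether the trifluoromethyl group itself matters or only the absence of the oxygen groups, which a plain phenyl would help to decide. Going by these compounds, how an aryl group carrying an amine or a carboxylic acid would behave at this position also remains open.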